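The source may hold more compounds than are shown below. What is called first, only, known or untested is meant among the compounds shown, and "the series" means these compounds.

Of the compounds shown here, two built on a shared core have so far been tested in a functional assay on MCF7 cells (Homo sapiens) for cytotoxicity, read by MTT assay, with a stated time of 72 h, tested at 1 uM; a higher number here means more inhibition of growth at the concentration tested, a lower number less inhibition of growth. Compound 1 `N/C(=N\NC(=S)N1CCOCC1)c1ccccn1` gives 14.7% in this assay. Compound 2 `Cc1ccnc(/C(N)=N/NC(=S)N2CCSCC2)c1` gives 3.89%, the lowest of the two numbers; its nearest neighbour, compound 1, lies higher by a gap that goes beyond the usual scatter of repeated measurements.

Compound 3 `N/C(=N\NC(=S)N1CCSCC1)c1ccccn1` has not yet been measured. It differs from compound 2 in one place only: hydrogen in place of methyl on an aromatic carbon. Within the data shown here, no pair of measured compounds differs by a single change, so nothing measured shows directly what this step does. Compound 3 shares the unsubstituted aromatic ring of compound 1 and the rest of its structure with compound 2, whose values in this assay differ by more than the scatter. The step from compound 2 to compound 3 is therefore expected to be small, if anything upward, and likely to stay within the scatter, as a number 5.1 percentage points higher from compound 2 to compound 3 (within the scatter) expresses. For compound 3 the expected result in this assay is 9%, with a range from 0% to 22%.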

Compound 3, percent growth inhibition at one concentration: 16.3%
For compound 3 the middle estimate is 7.3 percentage points below the measured one; low and high end bracket the measured number.
By their numbers in this assay, from the lowest: compound 2; then compounds 1 and 3 (each within the scatter of the next).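

In this assay, the place opposite the ring nitrogen now has a step that can be read directly: with thiomorpholin-4-yl held constant, hydrogen in place of methyl on this aromatic carbon gives a number 12.4 percentage points higher from compound 2 to compound 3 (beyond the scatter) and so matters in this small set. The other change, thiomorpholin-4-yl in place of morpholin-4-yl on the thiocarbonyl carbon, gives a number 1.6 percentage points higher from compound 1 to compound 3 (within the scatter) on the unsubstituted aromatic ring, so exchanging these two groups produces no readable change there. Nothing measured here offers an explanation for the step at the methyl position.

It remains open whether the methyl group would have a similar effect with morpholin-4-yl on the thiocarbonyl carbon, since the compounds shown test it only with thiomorpholin-4-yl. Going by these compounds, it is also open what other groups on this aromatic carbon, such as an ethyl chain, a methoxy group or an amine, would do, and whether the methyl step would hold at other concentrations in this assay or in other cell lines.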